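Swapping one fluorophenyl group for dimethoxyphenyl in compound 3

The source may hold more compounds than are shown below. What is called first, only, known or untested is meant among the compounds shown, and "the series" means these compounds.

Compound 1 `O=C1/C(=C/c2ccccc2F)CN(S(=O)(=O)c2ccc(F)cc2)C/C1=C\c1ccccc1F`: 8500 nM
Compound 2 `COc1cc(/C=C2\CN(S(=O)(=O)c3ccc(F)cc3)C/C(=C\c3cc(OC)c(OC)c(OC)c3)C2=O)cc(OC)c1OC`: 2220 nM
Compound 3 `CC(=O)Nc1ccc(S(=O)(=O)N2C/C(=C\c3ccccc3F)C(=O)/C(=C/c3ccccc3F)C2)cc1`: 5500 nM

In a functional assay on QGY-7703 cells (Homo sapiens) for cytotoxicity, read by MTT assay, with a stated time of 24 h (a lower number here means a stronger inhibitor, a higher number a weaker inhibitor), compound 3 gives 5500 nM, which is within the usual scatter of compound 1. Compound 2 gives 2220 nM, clearly the smallest number of the three. Among the compounds with values here, the only measured single change is a 1.5-fold lower number from compound 1 to compound 3 (0.19 log units; within the scatter), and it concerns the acetamido group, not the site altered next.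

Compound 4 `COc1cc(/C=C2\CN(S(=O)(=O)c3ccc(NC(C)=O)cc3)C/C(=C\c3ccccc3F)C2=O)cc(OC)c1` keeps that acetamido group and changes elsewhere: 3,5-dimethoxyphenyl in place of 2-fluorophenyl on a double-bonded chain carbon bound to a double-bonded ring carbon. In words, this is 3,5-dimethoxyphenyl in place of 2-fluorophenyl on a double-bonded chain carbon bound to a double-bonded ring carbon.

Within the data shown here, no measured step covers this swap directly. The closest hint is a pair of values: compound 1 at 8500 nM carries 2-fluorophenyl groups, where compound 2 at 2220 nM carries phenyl groups with methoxy substituents. That pair differs by more than this single swap, and its methoxy pattern is not the same, so only part of its gap is expected here. The estimate is a modest move towards a lower number, a 1.6-fold lower number from compound 3 to compound 4 (0.20 log units; within the scatter), which may stay within the scatter. Compound 4 is expected at 3500 nM, with an estimated range from 1500 nM to 7500 nM in this assay.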

Compound 4, half-maximal inhibitory concentration: 3690 nM
The estimate for compound 4 lay 1.1-fold (0.02 log units) below the measured number; measured number inside the range.
By their numbers in this assay, from the lowest: compounds 2, 4, 3 and 1 (each within the scatter of the next, the first and the last beyond it).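

In this assay the swap of 2-fluorophenyl for 3,5-dimethoxyphenyl on a double-bonded chain carbon bound to a double-bonded ring carbon gives a small step (a 1.5-fold lower number from compound 3 to compound 4 (0.17 log units; within the scatter)), so the two groups cannot be told apart at this position in this assay. Within the data shown here, this is the first direct reading at this position, and it shows that the entering group, with more heavy atoms and with hydrogen-bond acceptors that 2-fluorophenyl lacks, leaves the number within the scatter, even though compound 4 now carries two different groups on its double-bonded chain carbons where compound 3 carries the same group twice. No measurement shown here bears on why the number stays within the scatter.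

One swap on one background cannot show whether the same result would hold with the 4-fluorophenyl sulfonyl group of compound 1 in place of the acetamido group. From the compounds shown here alone, it also remains open whether a group of another kind at this position, such as an amine or a carboxylic acid on the phenyl ring, would move the number beyond the scatter.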